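The source may hold more compounds than are shown below. What is called first, only, known or untested is meant among the compounds shown, and "the series" means these compounds.

Compound 2, `COc1ccc([C@H]2CC(=O)N(c3cc(N)cc(F)c3)C2)cc1OC1CCCC1`, is the starting point of this comparison. In a functional assay on HEK293 cells (Homo sapiens) for cytotoxicity (on this read-out lower numbers stand for higher toxicity in this test and higher numbers for lower toxicity in this test), compound 2 gives > 10000 nM, which is a limit of the assay and not a number. The two other compounds in the set sit at the same kind of value. Compound 1, `COc1ccc([C@H]2CC(=O)N(c3ccc(N)cc3)C2)cc1OC1CCCC1`, gives > 10000 nM in this assay, again a limit. Compound 3, `COc1ccc([C@H]2CC(=O)N(c3cccnc3)C2)cc1OC1CCCC1`, gives > 10000 nM in this assay, also a limit. Within the data shown here, because of the limit of > 10000 nM in this assay, at which 3 of the 3 values shown sit, none of the measured steps can be read: a step that the two limits leave unreadable from compound 1 to compound 2, a step that the two limits leave unreadable from compound 1 to compound 3 and a step that the two limits leave unreadable from compound 2 to compound 3 all remain of unknown size, since every value involved is a limit.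

The compound to be measured is compound 4, `COc1ccc([C@H]2CC(=O)N(c3cccc([S+](C)[O-])c3)C2)cc1OC1CCCC1`. It differs from compound 2 as follows: a group of 9 heavy atoms (7 carbon, 1 oxygen, 1 sulfur; one six-membered aromatic ring of carbon only) in place of a group of 8 heavy atoms (6 carbon, 1 nitrogen, 1 fluorine; one six-membered aromatic ring of carbon only), on an amide-type nitrogen in a ring. Among the measured compounds shown here, each measured step that bears on this comparison, a change of the aromatic group on the amide-type nitrogen in a ring, is unreadable, so the only available information is that three such variations all stayed at the limit.

It is therefore expected that the step that the limit leaves unreadable from compound 2 to compound 4 stays within the scatter, with compound 4 most likely again reported as a limit. The estimated value for compound 4 in this assay is 15000 nM, within a range from 5000 nM to 50000 nM.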

Compound 4, half-maximal cytotoxic concentration: > 10000 nM
Compound 4 ended at the assay's limit (the forecaster's own chance of this, stated with the estimate: 85%); the middle value is on the limit's open side.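

The steps from compound 1, compound 2 and compound 3 to compound 4 cannot be read, because all the values involved are limits: the limit of > 10000 nM in this assay, at which 4 of the 4 values shown sit. The compounds shown leave open whether these groups on the amide-type nitrogen differ at all in this assay and at what concentration any of the four compounds would become cytotoxic.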